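Notes on the step from compound 2 to compound 4

This account rests on a few compounds, and the source may have more. Where it says the series, first, only, none or still open, it means among the compounds named here.

Measured in a functional assay on DU-145 cells (Homo sapiens) for inhibition, read by CCK-8 assay, with a stated time of 72 h; on this read-out higher numbers stand for weaker inhibition and lower numbers for stronger inhibition:
- compound 1 `O=C(/C=C/c1cccnc1)NCCCc1ccc(S(=O)(=O)Nc2ccccc2)cc1` gives > 10000 nM (a limit, not a number)
- compound 2 `O=C(/C=C/c1cccnc1)NCCCCCCc1cccc(S(=O)(=O)Nc2ccccc2)c1` gives 6.73 nM
- compound 3 `O=C(/C=C/c1cccnc1)NCCCCCCCc1cccc(S(=O)(=O)Nc2ccccc2)c1` gives 429 nM

Not yet measured: compound 4 `O=C(/C=C/c1cccnc1)NCCCCCCc1cccc(S(=O)(=O)Nc2ccc(F)cc2)c1`.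

Compound 1 stands at > 10000 nM, which is a limit of the assay and not a number. Among the measured compounds shown here, only two true numbers are therefore available. Compound 2 gives 6.73 nM, the lower of the two. Its nearest neighbour, compound 3, gives 429 nM, and that gap lies beyond the scatter.

Compound 4 keeps the structure of compound 2 except for one change: fluoro in place of hydrogen on an aromatic carbon, para to a large group (fluoro in place of hydrogen on an aromatic carbon). The same difference reads as phenylsulfamoyl to (4-fluorophenyl)sulfamoyl. For the measured compounds named here, no measured pair shows this change, so the expectation in this assay is a judgement from a single atom added to compound 2 at 6.73 nM.

The expected move is small and slightly toward weaker inhibition, with nothing beyond the scatter. The estimated step is a 1.3-fold higher number from compound 2 to compound 4 (0.13 log units; within the scatter). The range stays wide, as the series has already shown large gaps, with compound 3 at 429 nM. For compound 4 the expected value is 9 nM, with an estimated range of 2 nM to 50 nM.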

Compound 4, half-maximal inhibitory concentration: 10.6 nM
For compound 4 the middle estimate is 1.2-fold (0.07 log units) below the measured one; measured number inside the range.
By their numbers in this assay, from the lowest: compounds 2 and 4 (each within the scatter of the next); then compound 3. At a limit, above all of these: compound 1.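

In this assay, fluoro in place of hydrogen on this aromatic carbon gives a 1.6-fold higher number from compound 2 to compound 4 (0.20 log units; within the scatter), so the change leaves the read-out within the scatter. The earlier compounds shown here all carry the same unsubstituted phenylsulfamoyl group and differ only elsewhere, so this pair gives the series its first reading on that terminal ring. At this place, on the ring of carbon only and para to a large group, a single fluorine is accepted without a step beyond the scatter, and the phenylsulfamoyl to (4-fluorophenyl)sulfamoyl change therefore keeps compound 4 alongside compound 2. Nothing shown here bears on why the read-out holds at this place.

Going by these compounds, this single pair tests only one small atom, so it remains open whether the same aromatic carbon also accepts chloro, methoxy, trifluoromethyl, an amine or a carboxylic acid. On these data alone, it also remains open whether fluoro on the same ring would behave in the same way with the shorter or longer chains of the series, as the only chain tested with this change is that of compound 2.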